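A Larger Amine on the Propyl Chain of Compound 1

A few compounds are considered here, and "the series" means these few. Any claim that something is new, unique, unknown or untested is made for them only; others in the source may bear on it.

Two urea compounds have so far been measured in an assay on isolated protein for inhibition of ATP-dependent RNA helicase DDX3X (Homo sapiens), read by FRET, with stated times of 30 s and 40 min; a higher number here means a weaker inhibitor, a lower number a stronger inhibitor. Compound 1 `Cc1ccccc1NC(=O)Nc1ccc(-n2cc(CCCN(C)C)nn2)cc1` gives 2900 nM, the higher of the two numbers and so the weaker inhibitor. Compound 2 `CCCCc1cn(-c2ccc(NC(=O)Nc3cc(OCOC)ccc3C)cc2)nn1` gives 820 nM, a value far enough below that of compound 1 to lie beyond the usual scatter of repeated measurements. Compound 3 `Cc1ccccc1NC(=O)Nc1ccc(-n2cc(CCCN3CCN(C)CC3)nn2)cc1` has not yet been measured; it differs from compound 1 in a single place: 4-methylpiperazin-1-yl in place of dimethylamino on a saturated chain carbon, three bonds along the chain from an aromatic carbon. Among the measured compounds shown here, no measured pair in this set isolates that exact change, so its effect cannot be read from the numbers at hand. The expected step is a 1.5-fold lower number from compound 1 to compound 3 (0.16 log units; within the scatter), a small move toward a somewhat stronger inhibitor that may well fall within the scatter. Compound 3 is therefore estimated to give 2000 nM in this assay, with a likely range from 700 nM to 6000 nM.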

Compound 3, half-maximal inhibitory concentration: 40100 nM
Estimate against measurement, compound 3: 20-fold (1.30 log units) below, and the stated range ends below it.
By their numbers in this assay, from the lowest: compound 2; then compound 1; then compound 3.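

In this assay the change from dimethylamino to 4-methylpiperazin-1-yl on the propyl chain brings a 14-fold higher number from compound 1 to compound 3 (1.14 log units; beyond the scatter) and so a much weaker inhibitor. This shows that the position, on a saturated chain carbon three bonds along the chain from an aromatic carbon, is not indifferent to the group it carries: a swap in this one place, with the rest of compound 1 unchanged, moves the number well beyond the usual scatter. No measurement at hand bears on why the number rises.

On these data alone, the entering group adds a ring, more carbon and a second nitrogen all at once, and which of these matters remains open. A piperidine, a morpholine or a diethylamino group on the same propyl chain would help to separate them.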